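This account rests on a few compounds, and the source may have more. Where it says the series, first, only, none or still open, it means among the compounds named here.

Series of three compounds on the shared core, all read in an ADME assay on the whole organism (strain Sprague-Dawley) for pharmacokinetics, with Rattus norvegicus as the target, at a dose of 5 mg/kg by the oral route; on this read-out higher numbers stand for higher oral bioavailability and lower numbers for lower oral bioavailability. Compound 1 `COc1c(/C=C/c2ccc(NS(C)(=O)=O)cc2)cc(N2CCC(=O)NC2=O)cc1C(C)(C)C` gives 18%, the highest of the three numbers. Compound 2 `COc1c(C#Cc2ccc(NS(C)(=O)=O)cc2)cc(N2CCC(=O)NC2=O)cc1C(C)(C)C` gives 14%, a number within the scatter of compound 1, so no order can be set between them. Compound 3 `COc1c(C(=O)Nc2ccc(NS(C)(=O)=O)cc2)cc(N2CCC(=O)NC2=O)cc1C(C)(C)C` gives 1.4%, the furthest from compound 1 and beyond the scatter. Among the measured compounds shown here, no pair of measured compounds differs in only one place, so no single step can be drawn from the measured set.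

Compound 4 `COc1c(/C=C/c2ccc(NS(C)(=O)=O)cc2)cc(-n2ccc(=O)[nH]c2=O)cc1C(C)(C)C` has not been measured. Against compound 1 it differs in one place: a group of 8 heavy atoms (4 carbon, 2 nitrogen, 2 oxygen; one six-membered aromatic ring with 2 hetero atoms) in place of a group of 8 heavy atoms (4 carbon, 2 nitrogen, 2 oxygen; one six-membered non-aromatic ring with 2 hetero atoms), on an aromatic carbon. For the measured compounds named here, no measured pair shows a change of this kind, so its size cannot be read from the series. For compound 4 the expected step is a number 6 percentage points lower from compound 1 to compound 4 (within the scatter), a move within the scatter, leaning toward a lower number rather than a higher one. For compound 4 the estimated value is 12%, with a range from 4% to 28%.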

Compound 4, oral bioavailability: 44%
Compound 4: middle estimate off by 32 percentage points, on the low side; measured number outside the range, above it.
By their numbers in this assay, from the lowest: compound 3; then compounds 2 and 1 (each within the scatter of the next); then compound 4.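

Placing the six-membered aromatic ring with 2 hetero atoms on this aromatic carbon, para to a methoxy group, in place of the six-membered non-aromatic ring with 2 hetero atoms gives a number 26 percentage points higher from compound 1 to compound 4 (beyond the scatter) in this assay. Among the compounds shown here, this is the first single-place change, and it shows that this position can move oral bioavailability beyond the scatter with the heavy-atom count unchanged, while the count of hydrogen-bond acceptors differs between the two rings. Nothing at hand explains the size of this step.

From the compounds shown here alone, whether the same ring change carries over to the cores of compound 2 and compound 3 remains open, as the step rests on one pair. Also open, going by these compounds, is how an open-chain urea, a carboxylic acid or an amine on this aromatic carbon would read against either ring.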